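Hydroxy to Propanamide on the Piperidine-Bearing Core

The source may hold more compounds than are shown below. What is called first, only, known or untested is meant among the compounds shown, and "the series" means these compounds.

Going by the values given here, compound 2 `O=S1(=O)Cc2nc(-c3cc(F)c(Cl)cc3F)nc(N3CCC(O)CC3)c2C1` carries the only numerical solubility value shown: in a physicochemical assay for solubility, with a stated time of 20 h, at pH 6.8 (on this read-out higher numbers stand for higher solubility and lower numbers for lower solubility), compound 2 gives 91000 nM. Compound 1 `CN(C)C(=O)C1CCN(c2nc(-c3cc(F)c(Cl)cc3F)nc3c2CS(=O)(=O)C3)CC1` sits at the limit of > 100000 nM in this assay, at which 1 of the 2 values shown sits, reported only as > 100000 nM, a limit rather than a number. Among the compounds with values here, the single measured step, an at least 1.0-fold lower number from compound 1 to compound 2 (0.04 log units; that floor lies within the scatter), stays within the scatter. Compound 3 `NC(=O)CCC1CCN(c2nc(-c3cc(F)c(Cl)cc3F)nc3c2CS(=O)(=O)C3)CC1` differs from compound 2 by 2-carbamoylethyl in place of hydroxy on a saturated ring carbon. Since that one related step was small, no shift beyond the scatter is expected in this assay. Compound 3 is therefore expected to give 100000 nM, between 40000 nM and 250000 nM, amounting to a 1.1-fold higher number from compound 2 to compound 3 (0.04 log units; within the scatter).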

Compound 3, solubility: 8000 nM
The estimate for compound 3 lay 13-fold (1.10 log units) above the measured number, outside the stated range (below it).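

Going by these compounds alone, at this saturated ring carbon, three ring bonds from the ring nitrogen, the earlier compounds showed no step beyond the scatter, but in this assay the change to 2-carbamoylethyl gives an 11-fold lower number from compound 2 to compound 3 (1.06 log units; beyond the scatter). In place of dimethylcarbamoyl, the same group gives an at least 12-fold lower number from compound 1 to compound 3 (1.09 log units; beyond the scatter), so carrying a carbonyl and a nitrogen on this carbon does not by itself keep the number high. Compound 1 stands at a limit, not a number: the limit of > 100000 nM in this assay, at which 1 of the 3 values shown sits.

The compounds shown leave open whether the chain length or the terminal amide accounts for the lower number. A shorter chain, or a carboxylic acid or an amine at the end of the chain, would separate the two.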